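Halomethylsulfonyl variants: cytotoxicity on human fibroblast cells

The source may hold more compounds than are shown below. What is called first, only, known or untested is meant among the compounds shown, and "the series" means these compounds.

Measured so far:
compound 1 `NNc1ccc(S(=O)(=O)C(Cl)(Cl)Br)cc1[N+](=O)[O-]` — >= 16 ug/mL
compound 2 `NNc1ccc(S(=O)(=O)C(F)(F)I)cc1[N+](=O)[O-]` — >= 16 ug/mL

In an ADME assay on MRC5 cells (Homo sapiens) for cytotoxicity (on this read-out lower numbers stand for higher toxicity in this test and higher numbers for lower toxicity in this test), compound 2 gives only the limit >= 16 ug/mL, not a number. Compound 1 likewise stops at the limit >= 16 ug/mL. The step that the two limits leave unreadable from compound 1 to compound 2 is therefore not readable, both values sitting at the same limit (the limit of >= 16 ug/mL in this assay, at which 2 of the 2 values shown sit). Compound 3 `NNc1ccc(S(=O)(=O)C(F)(F)Cl)cc1[N+](=O)[O-]` differs from compound 2 by chloro in place of iodo on a saturated chain carbon bound to two fluorine atoms and a sulfonyl sulfur. For the measured compounds named here, no measured step is readable against this change, and both neighbours sit at the limit, so a step that the limit leaves unreadable from compound 2 to compound 3 is expected to be none beyond the scatter. Compound 3 is thus estimated at 20 ug/mL, within 10 ug/mL to 45 ug/mL, most likely again reported only as a limit.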

Compound 3, half-maximal cytotoxic concentration: >= 16 ug/mL
Compound 3 was reported as a limit (the forecaster's own chance of this, stated with the estimate: 75%); the middle value does not contradict the limit.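

No step between compound 1, compound 2 and compound 3 can be read in this assay, as each value is a limit and not a number: the limit of >= 16 ug/mL in this assay, at which 3 of the 3 values shown sit.

From the compounds shown here alone, whether any of these halogen exchanges on the sulfonyl-bound carbon changes cytotoxicity at all remains open.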